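Amide chain extension in the 2-oxoglutarate receptor 1 series

The compounds below may be only part of what the source reports. "The series", "measured", "known", "first", "only" and "open" are said of these compounds alone.

Measured so far:
compound 1 `NC(=O)[C@H]1OC(n2cnc3c(N)ncnc32)[C@H](O)[C@@H]1O` 64 nM
compound 2 `CCCCCCCCNC(=O)[C@H]1OC(n2cnc3c(N)ncnc32)[C@H](O)[C@@H]1O` 21 nM

Compound 2 stands lowest of the two numbers in an assay on cell membranes for binding affinity to 2-oxoglutarate receptor 1 (Rattus norvegicus), read by radioligand binding; on this read-out lower numbers stand for stronger inhibition and higher numbers for weaker inhibition; its nearest neighbour is compound 1 at 64 nM. Among the measured compounds shown here, the one measured step, a 3.0-fold lower number from compound 1 to compound 2 (0.48 log units; beyond the scatter), introduced octyl in place of hydrogen on an amide-type nitrogen. Compound 3 `CCCCCCCCCCCCNC(=O)[C@H]1OC(n2cnc3c(N)ncnc32)[C@H](O)[C@@H]1O` carries the change (butyl in place of hydrogen on a saturated chain carbon, eight bonds along the chain from an amide-type nitrogen), the same amide chain simply lengthened. That step bears directly on it, and a further lowering of about the same size or smaller is expected, since no second data point shows where the gain levels off. Compound 3 is therefore estimated at 12 nM, range 4 nM to 40 nM, a step of a 1.8-fold lower number from compound 2 to compound 3 (0.24 log units; within the scatter).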

Compound 3, inhibition constant: 163 nM
For compound 3 the middle estimate is 14-fold (1.13 log units) below the measured one; measured number outside the range, above it.
By their numbers in this assay, from the lowest: compound 2; then compound 1; then compound 3.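

In this assay the gain from lengthening the amide chain does not continue: butyl in place of hydrogen on a saturated chain carbon, eight bonds along the chain from an amide-type nitrogen, gives a 7.8-fold higher number from compound 2 to compound 3 (0.89 log units; beyond the scatter) and reverses the earlier lowering. Lengthening the chain at this position therefore does not keep lowering the number: compound 3 gives 163 nM, while compound 1 gives 64 nM on the same read-out. No available evidence accounts for this reversal.

Still open, on these data alone, is how a decyl chain on the amide nitrogen would read, and so where the turn lies between compound 2 and compound 3. Also open, as far as these compounds go, is whether a chain carrying an amine or a carboxylic acid would hold the number of compound 2.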